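Taking the Chloro Group Off Compound 3

The source may report more compounds than this note shows. Statements on the series, on what has been measured and on what is new or still open speak of the compounds shown alone.

Measured so far:
compound 1, `O=C1/C(=C2/C(=O)N([C@@H]3O[C@H](CO)[C@@H](O)[C@H](O)[C@H]3O)c3ccccc32)Nc2ccccc21`, 15700 nM
compound 2, `C[C@@H]1O[C@@H](N2C(=O)/C(=C3\Nc4ccccc4C3=O)c3ccccc32)[C@H](O)[C@H](O)[C@H]1O`, 760 nM
compound 3, `C[C@@H]1O[C@H](N2C(=O)/C(=C3\Nc4ccc(Cl)cc4C3=O)c3ccccc32)[C@H](O)[C@H](O)[C@H]1O`, 6960 nM

All three compounds were tested in a functional assay on MCF7 cells (Homo sapiens) for inhibition; on this read-out lower numbers stand for stronger inhibition and higher numbers for weaker inhibition. Among the three numbers, compound 3 stands second highest. Its nearest neighbour is compound 1, whose higher number lies beyond the usual scatter; its furthest neighbour is compound 2, whose much lower number also lies beyond the scatter.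

Compound 4, `C[C@@H]1O[C@H](N2C(=O)/C(=C3\Nc4ccccc4C3=O)c3ccccc32)[C@H](O)[C@H](O)[C@H]1O`, is the next compound to be measured in this assay. It differs from compound 3 in one place only: hydrogen in place of chloro on an aromatic carbon.

Among the compounds with values here, no pair of measured compounds differs by just this change, so there is no measured step to lean on. A chloro group leaving an aromatic carbon is a small change in size, and the expectation is a moderate move towards a lower number, that is towards stronger inhibition, rather than a large jump. Compound 4 is therefore expected to give about 2500 nM in this assay, within a range from 600 nM to 9000 nM. The step this estimate means, a 2.8-fold lower number from compound 3 to compound 4 (0.44 log units; beyond the scatter), is expected to exceed the scatter, though not by a wide margin.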

Compound 4, half-maximal inhibitory concentration: 670 nM
Beside the measured number, compound 4's estimate is 3.7-fold (0.57 log units) above it; measured number inside the range.
By their numbers in this assay, from the lowest: compounds 4 and 2 (each within the scatter of the next); then compound 3; then compound 1.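

Within the data shown here, the first measured step at this position is large: in this assay, hydrogen in place of chloro on this aromatic carbon, in the six-membered aromatic ring of carbon only, gives a 10-fold lower number from compound 3 to compound 4 (1.02 log units; beyond the scatter). For this pair, then, a single heavy atom at this position decides much of the inhibition seen in the assay, and the hydrogen form is clearly the better of the two. The second step, a 1.1-fold lower number from compound 2 to compound 4 (0.05 log units; within the scatter), shows that reversing one stereocentre at a saturated ring carbon leaves no readable difference, and this pair isolates that single stereocentre: the fact that compounds 2 and 4 differ only in the configuration as drawn

Only chloro and hydrogen are shown at this aromatic carbon, so it remains open whether a fluoro, a methoxy or an amine there would stay close to hydrogen or fall towards chloro. From the compounds shown here alone, it is also open whether the chloro step would be as large with the stereocentre drawn as in compound 2, and whether that stereocentre would still make no readable difference with chloro present.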